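From nitro to amino on a shared core

A few compounds are considered here, and "the series" means these few. Any claim that something is new, unique, unknown or untested is made for them only; others in the source may bear on it.

Measured so far in a functional assay on K562 cells (Homo sapiens) for cytotoxicity, read by trypan blue exclusion, with a stated time of 96 h; a higher number here means a weaker inhibitor, a lower number a stronger inhibitor:
Compound 1 `COc1ccc(NS(=O)(=O)/C=C/c2c(F)c(F)c(F)c(F)c2F)cc1F` gives 10000 nM
Compound 2 `COc1ccc(NS(=O)(=O)/C=C/c2c(F)c(F)c(F)c(F)c2F)cc1[N+](=O)[O-]` gives 100000 nM

Compound 2, at 100000 nM, holds the higher of the two numbers and is the weaker inhibitor of the pair. Compound 3 `COc1ccc(NS(=O)(=O)/C=C/c2c(F)c(F)c(F)c(F)c2F)cc1N` has not been measured. It differs from compound 2 by amino in place of nitro on an aromatic carbon, ortho to a methoxy group (amino in place of nitro on an aromatic carbon). For the measured compounds named here, one measured step bears on this change: nitro in place of fluoro on that same carbon gave a 10-fold higher number from compound 1 to compound 2 (1.00 log units; beyond the scatter) and counts as modest. Going by the values given here, no compound with the amino group has been measured, so the size remains uncertain. Losing the nitro group is expected to bring a step of similar size toward a stronger inhibitor in this assay. The estimate for compound 3 is 5000 nM within an expected range of 300 nM to 50000 nM in this assay. The expected result is a 20-fold lower number from compound 2 to compound 3 (1.30 log units; beyond the scatter) as estimated here.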

Compound 3, half-maximal inhibitory concentration: 75000 nM
For compound 3 the middle estimate is 15-fold (1.18 log units) below the measured one, outside the stated range (above it).
By their numbers in this assay, from the lowest: compound 1; then compounds 3 and 2 (each within the scatter of the next).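

In this assay, amino in place of nitro gives a 1.3-fold lower number from compound 2 to compound 3 (0.12 log units; within the scatter), so on this aromatic carbon, ortho to a methoxy group, the assay does not separate the two groups, even though they differ in heavy atoms and hydrogen-bond donors. Set against fluoro, amino gives a 7.5-fold higher number from compound 1 to compound 3 (0.88 log units; beyond the scatter), which shows that the higher number seen with nitro is not peculiar to nitro and that compound 1 stays apart from both compound 2 and compound 3. Nothing available explains this result.

From the compounds shown here alone, it remains open whether fluoro is itself favoured on this carbon or whether a chlorine, a hydroxyl or a methyl would give a similar or a lower number. Also open, going by these compounds, is whether the match between amino and nitro would hold if an ethoxy or a hydroxyl replaced the methoxy group.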